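The source may hold more compounds than are shown below. What is called first, only, known or untested is meant among the compounds shown, and "the series" means these compounds.

Measured compounds:
Compound 1 `COc1cc(-c2cc(C(=O)/C=C/c3ccc(Cl)cc3)nc3cc(-c4ccccc4)nn23)cc(OC)c1OC` gives 53900 nM in an ADME assay on HEK293 cells (Homo sapiens) for antiproliferative activity, read by MTT assay, with a stated time of 24 h; on this read-out higher numbers stand for weaker inhibition and lower numbers for stronger inhibition.
Compound 2 `COc1ccc(/C=C/C(=O)c2cc(-c3cc(OC)c(OC)c(OC)c3)n3nc(-c4ccccc4)cc3n2)cc1` gives 46600 nM in this assay.
Compound 3 `COc1ccc(-c2cc(C(=O)/C=C/c3cc(OC)c(OC)c(OC)c3)nc3cc(-c4ccccc4)nn23)cc1OC` gives 46800 nM in this assay.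

Compound 3 stands second highest of the three numbers, yet its gaps to compound 2 and to compound 1 both lie within the scatter, so the three compounds are not separable on these data. Compound 4 `COc1cc(/C=C/C(=O)c2cc(-c3cc(OC)c(OC)c(OC)c3)n3nc(-c4ccccc4)cc3n2)cc(OC)c1OC` differs from compound 3 by methoxy in place of hydrogen on an aromatic carbon. For the measured compounds named here, the only measured step, a 1.2-fold lower number from compound 1 to compound 2 (0.06 log units; within the scatter), concerns methoxy in place of chloro on the other aryl ring and stays within the scatter; no measured step exchanges hydrogen for methoxy. Because compound 1 gives 53900 nM and compound 3 gives 46800 nM in this assay with their methoxy groups placed differently, the move to compound 4 is expected to change little. The expected step is a 1.0-fold higher number from compound 3 to compound 4 (0.00 log units; within the scatter), with no direction beyond the scatter. Compound 4 is therefore estimated at 47000 nM, with a range from 25000 nM to 90000 nM.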

Compound 4, half-maximal inhibitory concentration: 41000 nM
Compound 4: the middle estimate sits 1.1-fold (0.06 log units) above what was measured; the range from low to high includes it.
By their numbers in this assay, from the lowest: compounds 4, 2, 3 and 1 (each within the scatter of the next).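

In this assay, the exchange of hydrogen for methoxy that turns 3,4-dimethoxyphenyl into 3,4,5-trimethoxyphenyl gives a 1.1-fold lower number from compound 3 to compound 4 (0.06 log units; within the scatter), so this position takes a further methoxy group without a step beyond the scatter. The aryl group on the double-bonded chain carbon behaves likewise: 3,4,5-trimethoxyphenyl in place of 4-methoxyphenyl gives a 1.1-fold lower number from compound 2 to compound 4 (0.06 log units; within the scatter), and in place of 4-chlorophenyl it gives a 1.3-fold lower number from compound 1 to compound 4 (0.12 log units; within the scatter), so with both aryl groups fully methoxylated the four compounds still cannot be separated. No measured evidence bears on this flat result.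

The aryl groups shown carry only methoxy or chloro substituents, so what an amine or a carboxylic acid at this position would give remains open. Going by these compounds, whether any change here can produce a step beyond the scatter also remains open.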